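Cell tolerance across a small set of aryl sulfonamides

The source may report more compounds than this note shows. Statements on the series, on what has been measured and on what is new or still open speak of the compounds shown alone.

Measured compounds:
- compound 1, `O=S(=O)(Nc1ccc(-c2nc3ccccc3o2)cc1)c1ccc(Cl)c(C(F)(F)F)c1`: 69000 nM
- compound 2, `O=S(=O)(Nc1ccc2oc(-c3ccccc3)nc2c1)c1ccccc1F`: 72000 nM
- compound 3, `O=S(=O)(Nc1ccc(-c2nc3ccccc3o2)cc1)c1ccccc1F`: a limit of > 100000 nM

All three were run in an ADME assay on HEK293 cells (Homo sapiens) for cytotoxicity, read by resazurin assay, with a stated time of 48 h; a higher number here means that more compound is tolerated, a lower number that less compound is tolerated. Compound 2 gives 72000 nM in this assay, and compound 1 gives 69000 nM; the two numbers lie within the usual scatter of each other, so compound 2 stands level with compound 1 on what has been measured. For compound 3 the assay reports only a limit, > 100000 nM, and not a number; that limit is the limit of > 100000 nM in this assay, at which 1 of the 3 values shown sits.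

The compound still to be measured is compound 4, `CCc1ccc(S(=O)(=O)Nc2ccc3oc(-c4ccccc4)nc3c2)cc1`. Compared with compound 2 it carries 4-ethylphenyl in place of 2-fluorophenyl on a sulfonyl sulfur.

Among the measured compounds shown here, no step between two measured compounds isolates such a change, so the expectation rests on the set as a whole, in which every measured compound is tolerated at a high concentration. The step from compound 2 to compound 4 is expected to be a 1.0-fold lower number from compound 2 to compound 4 (0.01 log units; within the scatter), that is, none beyond the scatter. Compound 4 is therefore estimated at 70000 nM in this assay, with a range from 30000 nM to 150000 nM.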

Compound 4, half-maximal cytotoxic concentration: 81000 nM
Compound 4: middle estimate off by 1.2-fold (0.06 log units), on the low side, and the stated range covers the measured number.
By their numbers in this assay, from the lowest: compounds 1, 2 and 4 (each within the scatter of the next). At a limit, above all of these: compound 3.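

In this assay, among the compounds shown here, compound 4 supplies the first step in this set that isolates a change on a sulfonyl sulfur whose other neighbour is the sulfonamide nitrogen: a 1.1-fold higher number from compound 2 to compound 4 (0.05 log units; within the scatter). At this place, 4-ethylphenyl and 2-fluorophenyl therefore stand level on the shared core, so removing the fluorine and adding the ethyl group together leave the number within the scatter. This single step cannot separate the fluorine from the ethyl group, and it speaks only for this pair.

As far as these compounds go, whether an amine or a carboxylic acid on this phenyl ring would move the number beyond the scatter remains open. Also open is how the same change would read on the core of compound 3, whose entry is a limit and not a number: the limit of > 100000 nM in this assay, at which 1 of the 4 values shown sits.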